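The compounds below may be only part of what the source reports. "The series", "measured", "known", "first", "only" and "open" are said of these compounds alone.

Three compounds have been measured so far:
compound 1 `Cc1cc(C)cc(NC(=O)COc2cc(C)nc3ccc(Cl)cc23)c1`, 8000 nM;
compound 2 `COc1ccc2nc(C)cc(OC3CCN(c4ccccc4)C3=O)c2c1`, 215000 nM;
compound 3 `COc1ccc2nc(C)cc(OCC(=O)Nc3cc(C)ccc3OC)c2c1`, 9500 nM.

These numbers come from a physicochemical assay for solubility, in phosphate buffer, measured as kinetic solubility, with a stated time of 1 h, at pH 7.4; a higher number here means a more soluble compound, a lower number a less soluble compound. Compound 3 sits close to compound 1, the two values lying within the scatter of one another, while compound 2 stands well higher, beyond the scatter. The next compound, compound 4 `COc1ccc2nc(C)cc(OCC(=O)Nc3cc(C)nc(C)n3)c2c1`, has not yet been measured in this assay. It differs from compound 3 in one place: 2,6-dimethylpyrimidin-4-yl in place of 2-methoxy-5-methylphenyl on an amide-type nitrogen. Among the measured compounds shown here, no measured pair shows this change, so there is nothing to calibrate its effect. The expected step of a 1.6-fold higher number from compound 3 to compound 4 (0.20 log units; within the scatter) is therefore small, a slight rise that may well stay within the scatter. On that basis compound 4 is expected to give about 15000 nM, plausibly between 4000 nM and 50000 nM.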

Compound 4, solubility: 5000 nM
Compound 4: middle estimate off by 3.0-fold (0.48 log units), on the high side; the range from low to high includes it.
By their numbers in this assay, from the lowest: compounds 4, 1 and 3 (each within the scatter of the next); then compound 2.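

In this assay, among the compounds shown here, putting 2,6-dimethylpyrimidin-4-yl in place of 2-methoxy-5-methylphenyl on the amide-type nitrogen gives a 1.9-fold lower number from compound 3 to compound 4 (0.28 log units; within the scatter) and is the first single-place change measured at this position. Exchanging an all-carbon aromatic ring for one with two hetero atoms therefore leaves the read-out within the scatter in this one pair. Nothing shown here accounts for the step.

This pair cannot separate the contribution of the ring nitrogens from that of the two methyl groups. As far as these compounds go, how a pyridine ring, or a phenyl ring bearing a carboxylic acid or an amine, would behave on this nitrogen remains open.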